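Ethynyl for thiophen-2-yl in the methoxy compound

The compounds below may be only part of what the source reports. "The series", "measured", "known", "first", "only" and "open" are said of these compounds alone.

Values in a functional assay on A549 cells (Homo sapiens), read by MTT assay, with a stated time of 72 h; on this read-out lower numbers stand for stronger inhibition and higher numbers for weaker inhibition:
- compound 1 `Nc1nc(N)c2c(-c3cccs3)cn([C@@H]3O[C@H](CO)[C@@H](O)[C@H]3O)c2n1`: > 20000 nM (a limit)
- compound 2 `COc1nc(N)nc2c1c(-c1cccs1)cn2[C@@H]1O[C@H](CO)[C@@H](O)[C@H]1O`: > 20000 nM (a limit)

In this assay compound 2 stands at > 20000 nM, which is a limit of the assay and not a number. Going by the values given here, the series so far offers only (the limit of > 20000 nM in this assay, at which 2 of the 2 values shown sit).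

The next change gives compound 3 `C#Cc1cn([C@@H]2O[C@H](CO)[C@@H](O)[C@H]2O)c2nc(N)nc(OC)c12`: ethynyl in place of thiophen-2-yl on an aromatic carbon, (ethynyl in place of thiophen-2-yl on an aromatic carbon). Among the compounds with values here, the only measured step is a step that the two limits leave unreadable from compound 1 to compound 2. Within the data shown here, it involves a different change, so no size carries over from it, and no measured compound here bears ethynyl. No direction can be derived from these data. A reading near the limit is expected for compound 3 because of the limit of > 20000 nM in this assay, at which 2 of the 2 values shown sit. The expected outcome is a number no higher from compound 2 to compound 3 (the limit leaves the size open). For compound 3 the estimate is 20000 nM, with an expected range of 6000 nM to 30000 nM.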

Compound 3, half-maximal inhibitory concentration: > 100000 nM
Compound 3: no number, only a limit; the forecaster's own chance of this, stated with the estimate: 80%; middle value at least 5.0-fold (0.69 log units) from the limit.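

Compound 2 and compound 3 both give only limits in this assay, not numbers, so the step between them cannot be read. The compounds shown leave open how the thiophen-2-yl and ethynyl compounds truly compare, and whether any change to the shared core gives a measurable value in this assay.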